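Removing a Fluoro from an Inactive Thiazole Hydrazone

This account rests on a few compounds, and the source may have more. Where it says the series, first, only, none or still open, it means among the compounds named here.

Compound 1 `Cc1nc(N(C)C(=O)NC(=O)c2c(F)cccc2F)sc1C(=O)N/N=C/c1ccccc1F` gives > 100 ug/mL in a functional assay on HepG2 cells (Homo sapiens) for inhibition, read by MTT assay, with a stated time of 72 h; a higher number here means a weaker inhibitor, a lower number a stronger inhibitor.
Compound 2 `CNc1nc(C)c(C(=O)N/N=C/c2cccc(C(F)(F)F)c2)s1` gives > 100 ug/mL in this assay.

Both of these values are limits of this assay rather than numbers, so compound 1 stands at the limit of > 100 ug/mL in this assay, at which 2 of the 2 values shown sit, and cannot be placed above or below compound 2. Compound 3 `Cc1nc(N(C)C(=O)NC(=O)c2c(F)cccc2F)sc1C(=O)N/N=C/c1ccccc1` differs from compound 1 only by hydrogen in place of fluoro on an aromatic carbon. With compound 1 at the limit, no step is expected beyond the usual scatter, and the result for compound 3 is most likely another limit. Compound 3 is estimated at 100 ug/mL (range 50 ug/mL to 200 ug/mL), meaning an expected step of a number no higher from compound 1 to compound 3 (the limit leaves the size open).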

Compound 3, half-maximal inhibitory concentration: 54.3 ug/mL
Estimate against measurement, compound 3: 1.8-fold (0.27 log units) above, and the stated range covers the measured number.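

For the compounds shown here, compound 3 is the first compound here to give a number rather than a limit: in this assay compound 3 gives 54.3 ug/mL. Going from 2-fluorophenyl to phenyl gives an at least 1.8-fold lower number from compound 1 to compound 3 (0.26 log units; that floor lies within the scatter), so this small change alone cannot yet be called a real gain. The full size of the step stays unknown because compound 1 is only a limit: the limit of > 100 ug/mL in this assay, at which 2 of the 3 values shown sit.

As far as these compounds go, whether an amine, a methoxy group or a chlorine at this place would give a lower number stays open. So does whether the same change acts alike on other compounds.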